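The source may report more compounds than this note shows. Statements on the series, on what has been measured and on what is new or still open speak of the compounds shown alone.

Compound 1 `COc1cc(-c2cc(/C=C/C(=O)c3ccc(N)cc3)[nH]n2)cc(OC)c1OC` gives 3580 nM in a functional assay on UACC-62 cells (Homo sapiens) for inhibition, read by sulforhodamine B assay, with a stated time of 48 h; a lower number here means a stronger inhibitor of growth, a higher number a weaker inhibitor of growth.
Compound 2 `COc1ccc(-c2cc(/C=C/C(=O)c3ccc(OC)c(OC)c3)[nH]n2)cc1` gives 3350 nM in this assay.
Compound 3 `COc1cc(-c2cc(/C=C/C(=O)c3ccc(Cl)c(Cl)c3)[nH]n2)cc(OC)c1OC` gives only a limit, > 100000 nM, in this assay.

Compound 1 stands highest of the two numbers shown, and compound 2 sits within the scatter of it, so the two cannot be told apart. Within the data shown here, the one measured step, an at least 27-fold higher number from compound 1 to compound 3 (1.44 log units; beyond the scatter), replaces the 4-aminophenyl on the carbonyl carbon and reaches the limit described by the limit of > 100000 nM in this assay, at which 1 of the 3 values shown sits; it is large, but it changes the other end of the shared core than the step considered here.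

Compound 4 `COc1ccc(-c2cc(/C=C/C(=O)c3ccc(N)cc3)[nH]n2)cc1OC` differs from compound 1 by hydrogen in place of methoxy on an aromatic carbon. Among the measured compounds shown here, no measured step changes this ring, so nothing bears directly on it. The values of compound 1 and compound 2, which carry different numbers of methoxy groups yet lie within the scatter of each other, suggest that methoxy count alone moves the number little. The step of a 1.1-fold higher number from compound 1 to compound 4 (0.05 log units; within the scatter) is therefore expected to stay within the scatter. For compound 4 the estimate is 4000 nM, with a range from 1500 nM to 12000 nM.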

Compound 4, concentration for total growth inhibition: 10900 nM
Compound 4: the middle estimate sits 2.7-fold (0.44 log units) below what was measured; measured number inside the range.
By their numbers in this assay, from the lowest: compounds 2 and 1 (each within the scatter of the next); then compound 4. At a limit, above all of these: compound 3.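

Hydrogen in place of methoxy gives a 3.0-fold higher number from compound 1 to compound 4 (0.48 log units; beyond the scatter) in this assay, the first measured step on this ring of the shared core. It shows that this position, ortho to a methoxy group and meta to a large group, is not indifferent to the change: losing this one methoxy group gives a modestly weaker inhibitor of growth, though compound 4 still gives a real number and not a limit. Nothing among the results shown explains why the number rises with this change.

Open, on these data alone, is whether methoxy itself matters here or whether another group would serve as well, such as a hydroxyl group, an ethoxy group or a fluorine atom. Also open, as far as these compounds go, is whether a hydroxyl group or a hydrogen at either remaining methoxy position of this ring would give a step of similar size.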